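The source may hold more compounds than are shown below. What is called first, only, known or untested is meant among the compounds shown, and "the series" means these compounds.

Measured compounds:
compound 2 `CCN1CCN(c2nc(NCc3ccc(OC)cc3)nc3c2ncn3CCCN2CCCC2)CC1`: 80 nM
compound 1 `CCN1CCN(c2nc(NCc3ccc(CN(C)C)cc3)nc3c2ncn3CCCN2CCCC2)CC1`: 90 nM

Among the measured compounds shown here, in an assay on HEK293 cells for antagonist activity at Toll-like receptor 9 (Homo sapiens), read by spectrophotometry (on this read-out lower numbers stand for stronger inhibition and higher numbers for weaker inhibition), compound 2 holds the lower of the two numbers, though the only measured step, a 1.1-fold lower number from compound 1 to compound 2 (0.05 log units; within the scatter), lies within the scatter, so the two are not separable. Compound 3 `CCN1CCN(c2nc(N)nc3c2ncn3CCCN2CCCC2)CC1` differs from compound 2 by hydrogen in place of 4-methoxybenzyl on a nitrogen on an aromatic ring. For the measured compounds named here, no measured step bears on this change; the one step known only swaps the substituent on that benzyl group and leaves the benzyl itself in place. Removing the whole group is expected to cost potency, a step of a 10-fold higher number from compound 2 to compound 3 (1.00 log units; beyond the scatter). Compound 3 is estimated at 800 nM in this assay, with a range of 150 nM to 5000 nM.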

Compound 3, half-maximal inhibitory concentration: 190 nM
Compound 3: middle estimate off by 4.2-fold (0.62 log units), on the high side, within the range that was stated.
By their numbers in this assay, from the lowest: compounds 2 and 1 (each within the scatter of the next); then compound 3.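

In this assay, removing the whole substituted benzyl from that nitrogen has a modest cost (a 2.4-fold higher number from compound 2 to compound 3 (0.38 log units; beyond the scatter)) and (a 2.1-fold higher number from compound 1 to compound 3 (0.32 log units; beyond the scatter)). Both steps lie beyond the scatter, so the benzyl groups add something, yet activity does not rest on them: compound 3, with the plain amino group, still gives (190 nM). Nothing measured bears on what lies behind these steps. Open, from the compounds shown here alone, is whether a smaller group on that nitrogen, such as methyl or acetyl, recovers the difference. Also open, going by these compounds, is whether a longer chain, such as 2-phenylethyl, or an amine on the ring does better than benzyl.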